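Ethoxy to Isopropoxy on the Benzylamide Side

The compounds below may be only part of what the source reports. "The series", "measured", "known", "first", "only" and "open" are said of these compounds alone.

Compound 1 `CCOc1ccc(CNC(=O)c2ccc(C(C)(C)C)cc2)cc1` carries the highest number among the three compounds measured in an assay on HeLa cells with Bile acid receptor (Homo sapiens) as the target, read by a luciferase reporter, with a stated time of 24 h; a higher number here means that more compound is needed for the effect, a lower number that less compound is needed: in this assay compound 1 gives 160 nM. Compound 2 `CC(C)(C)c1ccc(C(=O)NCc2ccc(C(=O)O)cc2F)cc1` gives 7.8 nM in this assay, and compound 3 `CC(C)(C)c1ccc(C(=O)NCc2ccc(NC(=O)C(F)(F)F)cc2Cl)cc1` gives 14 nM; both of these numbers lie beyond the scatter from that of compound 1, with compound 2 the furthest away and compound 3 the nearest. Compound 4 `CC(C)Oc1ccc(CNC(=O)c2ccc(C(C)(C)C)cc2)cc1` differs from compound 1 in one place: methyl in place of hydrogen on a saturated chain carbon bound to an oxygen on an aromatic ring and a saturated chain carbon. Within the data shown here, no step between two measured compounds in this set has the same change, so the measured numbers give no direct reading of what one added methyl at this position does. The change is small, a single carbon on the chain of an alkoxy group. The step of a 1.1-fold lower number from compound 1 to compound 4 (0.03 log units; within the scatter) is therefore expected to stay within the usual scatter, in no firm direction. Compound 4 is estimated at 150 nM, within a range from 60 nM to 400 nM.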

Compound 4, half-maximal effective concentration: 170 nM
The estimate for compound 4 lay 1.1-fold (0.05 log units) below the measured number; low and high end bracket the measured number.
By their numbers in this assay, from the lowest: compounds 2 and 3 (each within the scatter of the next); then compounds 1 and 4 (each within the scatter of the next).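

Going from ethoxy to isopropoxy gives a 1.1-fold higher number from compound 1 to compound 4 (0.03 log units; within the scatter) in this assay, the first direct reading of this position among the compounds shown. On this single step, the saturated chain carbon bound to the oxygen on the aromatic ring accepts one added methyl without a change that can be told apart from the scatter, so the two compounds cannot be ranked. No measurement offered here explains this result.

A single step cannot show whether this holds for larger groups at the same place, such as a longer chain like butoxy or a cyclopropyl ring. It also leaves open what an amine or a carboxylic acid would do in place of the alkoxy group on the core of compound 1.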